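The source may hold more compounds than are shown below. What is called first, only, known or untested is meant among the compounds shown, and "the series" means these compounds.

Compound 1, `O=C1NCCN1c1ccc(S(=O)(=O)Nc2cccc(Oc3ccccc3)c2)cc1`, gives 200 nM in a functional assay on HT-29 cells (Homo sapiens) for antiproliferative activity, read by sulforhodamine B assay, with a stated time of 48 h; on this read-out higher numbers stand for weaker inhibition and lower numbers for stronger inhibition.
Compound 2, `Cc1cccc(NS(=O)(=O)c2ccc(N3CCNC3=O)cc2)c1C`, gives 190 nM in this assay.
Compound 3, `Cc1cccc(NS(=O)(=O)c2ccc(N3CCNC3=O)cc2)c1`, gives 110 nM in this assay.

Compound 3 carries the smallest of the three numbers, but the distances to its neighbours, a 1.7-fold lower number from compound 2 to compound 3 (0.24 log units; within the scatter) and a 1.8-fold lower number from compound 1 to compound 3 (0.26 log units; within the scatter), both fall within the scatter, so none of the three compounds can be called more or less active than another.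

The next compound, compound 4, `O=C1NCCN1c1ccc(S(=O)(=O)Nc2cccc(Cl)c2)cc1`, differs from compound 3 in one place: chloro in place of methyl on an aromatic carbon. For the measured compounds named here, two measured steps bear on this change. The step of a 1.8-fold lower number from compound 1 to compound 3 (0.26 log units; within the scatter) alters the same aromatic carbon, exchanging phenoxy for methyl, and stays within the scatter. The step of a 1.7-fold lower number from compound 2 to compound 3 (0.24 log units; within the scatter) removes a methyl from a neighbouring aromatic carbon and also stays within the scatter. Neither step shows that the substituent at this position moves the number in this assay beyond the scatter, so no step beyond the scatter is expected for the exchange of methyl for chloro either.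

Compound 4 is therefore expected to give about 120 nM in this assay, with a range of 55 nM to 260 nM. This estimate corresponds to an expected step of a 1.1-fold higher number from compound 3 to compound 4 (0.04 log units; within the scatter), within the scatter.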

Compound 4, half-maximal inhibitory concentration: 55 nM
For compound 4 the middle estimate is 2.2-fold (0.34 log units) above the measured one, and the stated range covers the measured number.
By their numbers in this assay, from the lowest: compounds 4, 3, 2 and 1 (each within the scatter of the next, the first and the last beyond it).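

In this assay the exchange of methyl for chloro on this aromatic carbon, meta to a large group, does not separate the two compounds: a 2.0-fold lower number from compound 3 to compound 4 (0.30 log units; within the scatter) is printed as within the scatter, so neither compound can be ranked above the other. What is new is that the series now contains steps beyond the scatter, which none of the first three compounds showed among themselves: a 3.6-fold lower number from compound 1 to compound 4 (0.56 log units; beyond the scatter) exchanges phenoxy for chloro on the same carbon, and a 3.5-fold lower number from compound 2 to compound 4 (0.54 log units; beyond the scatter) exchanges 2,3-dimethylphenyl for 3-chlorophenyl on the sulfonamide nitrogen, both modest in size. No measurement at hand bears on what lies behind these steps.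

Only methyl, chloro and phenoxy are compared on this carbon, so the compounds shown leave open whether fluoro, methoxy or an amine there would give a number that stands apart from that of compound 4. They also leave open whether a carboxylic acid at this place would keep the number in the same range as compound 3 and compound 4 or move it beyond the scatter.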